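The source may hold more compounds than are shown below. What is called first, only, known or untested is meant among the compounds shown, and "the series" means these compounds.

Within the data shown here, in a functional assay on NCI-H460 cells (Homo sapiens) for cytotoxicity, read by sulforhodamine B assay, with a stated time of 3 days (a lower number here means a stronger inhibitor, a higher number a weaker inhibitor), compound 1 `OCc1cn(Cc2cccc(I)c2)c2ccccc12` gives 100 nM and compound 2 `Cc1cccc(Cn2cc(CO)c3ccccc32)c1` gives 31 nM, the lower of the two numbers measured so far. Compound 3 `O=[N+]([O-])c1cccc(Cn2cc(CO)c3ccccc32)c1` keeps the core of compound 2 and alters one group, with nitro in place of methyl on an aromatic carbon, meta to a large group (nitro in place of methyl on an aromatic carbon). Among the measured compounds shown here, one measured step bears on this change, since it involves the same aromatic carbon: methyl in place of iodo gave a 3.2-fold lower number from compound 1 to compound 2 (0.51 log units; beyond the scatter), a modest step. For the measured compounds named here, this shows that the group at this carbon can shift the number, but no nitro compound has been measured, so the direction remains uncertain. A modest step towards a higher number in this assay is the cautious expectation, and the estimated change is a 1.9-fold higher number from compound 2 to compound 3 (0.29 log units; within the scatter). For compound 3, the expected value is 60 nM, with an estimated range of 15 nM to 240 nM.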

Compound 3, half-maximal inhibitory concentration: 39 nM
Compound 3: the middle estimate sits 1.5-fold (0.19 log units) above what was measured; measured number inside the range.
By their numbers in this assay, from the lowest: compounds 2 and 3 (each within the scatter of the next); then compound 1.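

In this assay nitro in place of methyl gives a 1.3-fold higher number from compound 2 to compound 3 (0.10 log units; within the scatter) and this lies within the scatter, so this change separates compound 2 and compound 3 by no meaningful amount even though the two groups differ in heavy atoms and hydrogen-bond acceptors. Nitro in place of iodo gives a 2.6-fold lower number from compound 1 to compound 3 (0.41 log units; beyond the scatter) and this lies beyond the scatter, so the earlier gain from removing iodo is no longer tied to methyl alone: among these three compounds, iodo is the group that stands apart. No measurement given here explains this similarity or that gap.

Going by these compounds, whether an amine or a carboxylic acid on this same aromatic carbon would stay with compound 2 and compound 3 or move towards compound 1 remains open. The compounds shown also leave open whether methyl and nitro would match each other on another carbon of this ring.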